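Diethylamino in place of piperidin-1-yl on compound 1

The compounds below may be only part of what the source reports. "The series", "measured", "known", "first", "only" and "open" are said of these compounds alone.

Working notes on the series. In an assay on CHO cells for inhibition of Vasopressin V2 receptor (Homo sapiens), read by radioligand binding (a lower number here means a stronger inhibitor, a higher number a weaker inhibitor), compound 1 `O=C(Nc1ccc(C(=O)N2CCCCc3sccc32)cc1OCCCC(=O)N1CCC(N2CCCCC2)CC1)c1ccccc1-c1ccccc1` gives 30 nM, the higher of the two numbers recorded; compound 2 `COc1cc(C(=O)N2CCCC(N(C)C)c3sccc32)ccc1NC(=O)c1ccccc1-c1ccccc1` gives 20 nM, and the gap between them lies within the usual scatter, so no order between the two is claimed. In this assay compound 3 `O=C(Nc1ccc(C(=O)N2CCCCc3sccc32)cc1O)c1ccccc1-c1ccccc1` returns only a limit of the assay, < 10 nM; the limit of < 10 nM in this assay, at which 1 of the 3 values shown sits, marks where that value sits. Going by the values given here, no pair of measured compounds differs in a single place, so no measured step guides the change. Compound 4 `CCN(CC)C1CCN(C(=O)CCCOc2cc(C(=O)N3CCCCc4sccc43)ccc2NC(=O)c2ccccc2-c2ccccc2)CC1` differs from compound 1 by diethylamino in place of piperidin-1-yl on a saturated ring carbon. The expected step is no change at the digits printed from compound 1 to compound 4 (within the scatter), none beyond the scatter. Compound 4 is therefore estimated at 30 nM, within 10 nM to 90 nM.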

Compound 4, half-maximal inhibitory concentration: 9 nM
Compound 4: middle estimate off by 3.3-fold (0.52 log units), on the high side; measured number below the stated range.
By their numbers in this assay, from the lowest: compound 4; then compounds 2 and 1 (each within the scatter of the next).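

In this assay, diethylamino in place of piperidin-1-yl on the saturated ring carbon gives a 3.3-fold lower number from compound 1 to compound 4 (0.52 log units; beyond the scatter). Going by these compounds alone, this is the first measured single-place step, and it shows that the number responds to the group at this position and that the piperidin-1-yl ring is not required there. Compound 3 stands only as a limit, not a number: the limit of < 10 nM in this assay, at which 1 of the 4 values shown sits.

From the compounds shown here alone, whether pyrrolidin-1-yl, morpholin-4-yl or a primary amine at this position would move the number further stays open. So does whether the same change would hold on a shorter chain.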